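Isatin-derived series: substituent change at the double-bonded nitrogen

The source may hold more compounds than are shown below. What is called first, only, known or untested is meant among the compounds shown, and "the series" means these compounds.

Measured so far in a functional assay on HCT-116 cells (Homo sapiens) for cytotoxicity, read by sulforhodamine B assay, with a stated time of 24 h; on this read-out lower numbers stand for stronger inhibition and higher numbers for weaker inhibition:
compound 1 `O=C1Nc2ccc(S(=O)(=O)N3CCOCC3)cc2/C1=N/NC(=O)c1ccccc1` gives 28900 nM
compound 2 `N#CCC(=O)N/N=C1\C(=O)Nc2ccc(S(=O)(=O)N3CCOCC3)cc21` gives 10300 nM
compound 3 `O=C1Nc2ccc(S(=O)(=O)N3CCOCC3)cc2/C1=N/NS(=O)(=O)c1ccccc1` gives 13300 nM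

Compound 3 stands second highest of the three numbers, close to compound 2 and apart from compound 1: a 2.2-fold lower number from compound 1 to compound 3 (0.34 log units; beyond the scatter), while a 1.3-fold higher number from compound 2 to compound 3 (0.11 log units; within the scatter).

Compound 4 `O=C1Nc2ccc(S(=O)(=O)N3CCOCC3)cc2/C1=N/c1cccc(C(F)(F)F)c1` follows from compound 3 by 3-(trifluoromethyl)phenyl in place of (phenylsulfonyl)amino on a double-bonded nitrogen. Within the data shown here, no measured step covers this exchange. The steps that do touch this part of the core, a 2.8-fold lower number from compound 1 to compound 2 (0.45 log units; beyond the scatter) and a 2.2-fold lower number from compound 1 to compound 3 (0.34 log units; beyond the scatter), were both modest, so a step of similar size or none beyond the scatter is expected here: a 1.1-fold higher number from compound 3 to compound 4 (0.05 log units; within the scatter). Compound 4 is therefore estimated at 15000 nM, within 5000 nM to 45000 nM.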

Compound 4, half-maximal inhibitory concentration: 15900 nM
Beside the measured number, compound 4's estimate is 1.1-fold (0.03 log units) below it; the range from low to high includes it.
By their numbers in this assay, from the lowest: compounds 2, 3, 4 and 1 (each within the scatter of the next, the first and the last beyond it).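

In this assay, a direct aryl group on the double-bonded nitrogen matches the acylated and sulfonylated amino groups within the scatter, with a 1.2-fold higher number from compound 3 to compound 4 (0.08 log units; within the scatter) and a 1.5-fold higher number from compound 2 to compound 4 (0.19 log units; within the scatter) and a 1.8-fold lower number from compound 1 to compound 4 (0.26 log units; within the scatter). Exchanging (phenylsulfonyl)amino for 3-(trifluoromethyl)phenyl removes the hydrogen-bond donor and acceptors counted on the leaving group, with no change beyond the scatter. Nothing on hand explains this result.

As far as these compounds go, whether an amine, a carboxylic acid or a longer chain in place of 3-(trifluoromethyl)phenyl would shift the number beyond the scatter remains open.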